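Solubility notes: compound 3 to compound 4

The source may report more compounds than this note shows. Statements on the series, on what has been measured and on what is new or still open speak of the compounds shown alone.

The series shares one core. Compound 1 `CNC(=O)c1cc(Oc2ccc3nc(Nc4ccccc4)ncc3c2)ccn1` carries an unsubstituted phenyl on the nitrogen; in a physicochemical assay for solubility, at pH 7 (a lower number here means a less soluble compound, a higher number a more soluble compound), compound 1 gives < 1000 nM, which is a limit of the assay and not a number. Compound 2 `CNC(=O)c1cc(Oc2ccc3nc(Nc4cccc(C(C)(C)C)c4)ncc3c2)ccn1` carries tert-butyl on an aromatic carbon; in this assay compound 2 gives < 1000 nM, again a limit. Compound 3 `CNC(=O)c1cc(Oc2ccc3nc(Nc4cccc(C(C)C)c4)ncc3c2)ccn1` carries isopropyl in the same way; in this assay compound 3 gives < 1000 nM, also a limit. Compound 3 therefore stands at the same limit as its two neighbours (the limit of < 1000 nM in this assay, at which 3 of the 3 values shown sit), and the steps a step that the two limits leave unreadable from compound 1 to compound 2, a step that the two limits leave unreadable from compound 1 to compound 3 and a step that the two limits leave unreadable from compound 2 to compound 3 cannot be read in size or direction. Compound 4 `CNC(=O)c1cc(Oc2ccc3nc(Nc4ccc(F)cc4)ncc3c2)ccn1` arises by 4-fluorophenyl in place of 3-isopropylphenyl on a nitrogen on an aromatic ring. Among the compounds with values here, no measured step bears readably on this change because every value so far sits at the limit (the limit of < 1000 nM in this assay, at which 3 of the 3 values shown sit). Compound 4 is estimated at 500 nM, between 100 nM and 2000 nM, most likely reported again as a limit. The step that the limit leaves unreadable from compound 3 to compound 4 is expected to be none beyond the scatter, though unreadable against a limit.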

Compound 4, solubility: < 1000 nM
Compound 4 ended at the assay's limit (the forecaster's own chance of this, stated with the estimate: 75%); the middle value does not contradict the limit.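

Compound 4 sits at the same limit as compound 1, compound 2 and compound 3, so none of the steps among these compounds can be read in this assay: the limit of < 1000 nM in this assay, at which 4 of the 4 values shown sit. The compounds shown leave open whether phenyl, 3-(tert-butyl)phenyl, 3-isopropylphenyl and 4-fluorophenyl differ at all in this read-out, and in which direction.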